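From acetyl to (tert-butyl)carbonyl: working notes on compound 4

The source may hold more compounds than are shown below. What is called first, only, known or untested is meant among the compounds shown, and "the series" means these compounds.

Values so far in a functional assay on the whole organism for inhibition, with Rattus norvegicus as the target, read by paw edema, with stated times of 1 h and 3 h; a lower number here means that less compound is needed, a higher number that more compound is needed for the effect:
Compound 1 `CCOC(=O)CO/N=C(\C)c1ccc(Cl)cc1` gives 32 mg/kg
Compound 2 `C/C(=N\OCCO)c1ccc(Cl)cc1` gives 29 mg/kg
Compound 3 `CC(=O)OCCO/N=C(\C)c1ccc(Cl)cc1` gives 43 mg/kg

Compound 3 at 43 mg/kg is not separated from the other two values. Two of the measured steps, a 1.1-fold lower number from compound 1 to compound 2 (0.04 log units; within the scatter) and a 1.3-fold higher number from compound 1 to compound 3 (0.13 log units; within the scatter), stay within the scatter. Compound 4 `C/C(=N\OCCOC(=O)C(C)(C)C)c1ccc(Cl)cc1` differs from compound 3 by tert-butyl in place of methyl on a carbonyl carbon. For the measured compounds named here, no measured step changes this group itself. The nearest change, acetyl in place of hydrogen, was a 1.5-fold higher number from compound 2 to compound 3 (0.17 log units; within the scatter), so no shift beyond the scatter is expected in this assay. The expected step is a 1.1-fold lower number from compound 3 to compound 4 (0.05 log units; within the scatter). Compound 4 is estimated at 38 mg/kg, with an expected range of 19 mg/kg to 75 mg/kg.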

Compound 4, dose for half-maximal effect: 38 mg/kg
Beside the measured number, compound 4's estimate shows no gap at the digits printed; the range from low to high includes it.
By their numbers in this assay, from the lowest: compounds 2, 1, 4 and 3 (each within the scatter of the next).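

Tert-butyl in place of methyl on a carbonyl carbon, the first measured change at this group itself, gives a 1.1-fold lower number from compound 3 to compound 4 (0.05 log units; within the scatter) in this assay. Read from the hydrogen, (tert-butyl)carbonyl on the oxygen gives a 1.3-fold higher number from compound 2 to compound 4 (0.12 log units; within the scatter), so this acyl group, like acetyl, stays within the scatter of the unacylated compound 2. Nothing available explains this result.

As far as these compounds go, whether an amine or a phenyl group in place of tert-butyl on this carbonyl carbon would give a step beyond the scatter remains open.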